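This account rests on a few compounds, and the source may have more. Where it says the series, first, only, none or still open, it means among the compounds named here.

In a functional assay on the whole organism for agonist activity, with Mus musculus as the target (on this read-out higher numbers stand for an effect only at larger amounts of compound and lower numbers for an effect already at smaller amounts), compound 1 `CC(=O)N(C)C(C)C#CCn1ccnc1` gives 3 mg/kg. Compound 2 `CC(=O)N(C)C(C)C#CCn1ccnc1C` gives > 100 mg/kg, which is a limit of the assay and not a number. Compound 3 `COC(=O)N(C)C(C)C#CCn1ccnc1` gives 8 mg/kg.

The change methyl in place of hydrogen on an aromatic carbon produced an at least 33-fold higher number from compound 1 to compound 2 (1.52 log units; beyond the scatter), with compound 2 sitting at the limit of > 100 mg/kg in this assay, at which 1 of the 3 values shown sits. The two cores differ by methoxy in place of methyl on a carbonyl carbon, a step of a 2.7-fold higher number from compound 1 to compound 3 (0.43 log units; beyond the scatter); compound 3 therefore has the higher of the two numbers.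

Compound 4 `COC(=O)N(C)C(C)C#CCn1cncc1C`, not yet measured, carries methyl in place of hydrogen on an aromatic carbon. This is the same kind of change as that from compound 1 to compound 2, not the same: in compound 2 the methyl sits between two ring nitrogen atoms, in compound 4 next to the ring nitrogen and two ring bonds from the ring nitrogen, in both cases next to the ring atom that bears a large group. Because the same kind of change gave an at least 33-fold higher number from compound 1 to compound 2 (1.52 log units; beyond the scatter), a large step is expected from compound 3 to compound 4 as well, with the different place leaving room for a smaller one. For compound 4 in this assay a step of a 5.0-fold higher number from compound 3 to compound 4 (0.70 log units; beyond the scatter) is expected, and its value is estimated at 40 mg/kg, between 8 mg/kg and 150 mg/kg.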

Compound 4, dose for half-maximal effect: > 100 mg/kg
Compound 4: no number, only a limit; the forecaster's own chance of this, stated with the estimate: 35%; middle value at least 2.5-fold (0.39 log units) away from the limit.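

In this assay, methyl in place of hydrogen on an aromatic carbon gives an at least 12-fold higher number from compound 3 to compound 4 (1.09 log units; beyond the scatter), so a large step to a higher number appears on the core of compound 3 as it did on the core of compound 1, even though the methyl sits at a different place on the ring. The two steps can be compared only as far as the limits allow: the same change on two cores in this assay, an at least 33-fold higher number (1.52 log units; beyond the scatter) from compound 1 to compound 2 and an at least 12-fold higher number (1.09 log units; beyond the scatter) from compound 3 to compound 4; the limit leaves it open whether they differ. Compound 2 and compound 4 each give a limit and not a number, so the full size of neither step is shown, and the data do not establish whether place or core changes the effect: the limit of > 100 mg/kg in this assay, at which 2 of the 4 values shown sit.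

The compounds shown leave open whether a group other than methyl on these ring carbons, such as fluorine or chlorine, would produce a step of similar size. They also leave open how the change reads on a core with an ethyl group or a longer chain in place of the methyl on the chain nitrogen.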